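Hydroxy Removal on the Hydrazone Aryl Ring in Pyrimidine Diones

This account rests on a few compounds, and the source may have more. Where it says the series, first, only, none or still open, it means among the compounds named here.

Measured compounds:
compound 1 `Cn1c(=O)c(=O)n(C2CCCC2)c2nc(N/N=C/c3ccccc3)ncc21` – 48200 nM
compound 2 `Cn1c(=O)c(=O)n(C2CCCC2)c2nc(N/N=C/c3ccc(O)cc3)ncc21` – > 100000 nM
compound 3 `Cn1c(=O)c(=O)n(C2CCCC2)c2nc(N/N=C/c3cc(C(F)(F)F)c(O)c(C(F)(F)F)c3)ncc21` – 17700 nM

Three analogues sharing one core were tested in a functional assay on PC-3 cells (Homo sapiens) for antiproliferative activity, read by MTT assay; on this read-out higher numbers stand for weaker inhibition and lower numbers for stronger inhibition. Compound 1 gives 48200 nM. For compound 2 the reading is a limit of the assay, > 100000 nM, which matches (the limit of > 100000 nM in this assay, at which 1 of the 3 values shown sits). Compound 3 gives 17700 nM.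

The pair 2 and 1 differ as hydrogen in place of hydroxy on an aromatic carbon, and this gives an at least 2.0-fold lower number from compound 2 to compound 1 (0.31 log units; beyond the scatter). The difference between the cores of compound 2 and compound 3 is not broken down here.

Compound 4 `Cn1c(=O)c(=O)n(C2CCCC2)c2nc(N/N=C/c3cc(C(F)(F)F)cc(C(F)(F)F)c3)ncc21` remains unmeasured. It differs from compound 3 as hydrogen in place of hydroxy on an aromatic carbon. This is the same kind of change as from compound 2 to compound 1, but around the place it is not the same: in compound 3 the hydroxy sits ortho to two trifluoromethyl groups, which are absent in compound 2. Resting on the step from compound 2 to compound 1, compound 4 is expected to show a 1.8-fold lower number from compound 3 to compound 4 (0.25 log units; within the scatter), a modest change in the same direction. Compound 4 is therefore estimated at 10000 nM, with a likely range from 3500 nM to 35000 nM.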

Compound 4, half-maximal inhibitory concentration: 8200 nM
Compound 4: the middle estimate sits 1.2-fold (0.09 log units) above what was measured; the measured number falls inside the stated range.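

In this assay, hydrogen in place of hydroxy, on a ring where the hydroxy sits ortho to two trifluoromethyl groups, gives a 2.2-fold lower number from compound 3 to compound 4 (0.33 log units; beyond the scatter). The same change therefore lowers the number in both pairs, although the earlier step rests on a limit of the assay: the same change on two cores in this assay, an at least 2.0-fold lower number (0.31 log units; beyond the scatter) from compound 2 to compound 1 and a 2.2-fold lower number (0.33 log units; beyond the scatter) from compound 3 to compound 4; the limit leaves it open whether they differ Across these two pairs the direction of the change carries over, with or without the two trifluoromethyl groups, but the size of the earlier step remains a bound rather than a number, so it cannot be said that the size carries over too, and two pairs set no rule for the wider series.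

The compounds shown leave open whether a methoxy group or an amine in place of the hydroxy would lower the number as hydrogen does. They also leave open whether the step would look the same with a single trifluoromethyl group or with chlorine on the ring.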